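Pentyl Extension of a Hydroxyalkyl Side Chain on Two Cores

The compounds below may be only part of what the source reports. "The series", "measured", "known", "first", "only" and "open" are said of these compounds alone.

Measured compounds:
compound 1 `COc1cc(CO)c(OC)c2c1C(=O)C=CC2=O`: 0.062 ug/mL
compound 2 `CCCCCC(O)c1cc(OC)c2c(c1OC)C(=O)C=CC2=O`: 0.066 ug/mL
compound 3 `COc1ccc(OC)c2c1C(=O)C=C(C(C)O)C2=O`: 0.487 ug/mL

All three were tested in a functional assay on L1210 cells (Mus musculus) for cytotoxicity; a lower number here means that less compound is needed, a higher number that more compound is needed for the effect. Compound 2 differs from compound 1 by pentyl in place of hydrogen on a saturated chain carbon bound to an aromatic carbon and an oxygen on a saturated carbon. That change gave a 1.1-fold higher number from compound 1 to compound 2 (0.03 log units; within the scatter). Compound 3 carries its hydroxyalkyl group on a different part of the core, and the difference between its core and that of compound 1 is not broken down here; its number is the highest of the three, well beyond the scatter from both compound 1 and compound 2.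

Compound 4 `CCCCCCC(O)C1=CC(=O)c2c(OC)ccc(OC)c2C1=O` has not yet been measured. It differs from compound 3 by pentyl in place of hydrogen on a saturated chain carbon, two bonds along the chain from a double-bonded ring carbon and an oxygen on a saturated carbon. This is the same kind of change as that from compound 1 to compound 2, though the place differs: in compound 2 the saturated chain carbon is bound to an aromatic carbon, whereas in compound 4 it is two bonds along the chain from a double-bonded ring carbon. Since a 1.1-fold higher number from compound 1 to compound 2 (0.03 log units; within the scatter) lay within the scatter, the step to compound 4 is expected to be similarly small, a 1.0-fold higher number from compound 3 to compound 4 (0.01 log units; within the scatter). Compound 4 is therefore estimated at 0.5 ug/mL, with a likely range from 0.2 ug/mL to 1.3 ug/mL.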

Compound 4, concentration for half-maximal effect: 0.732 ug/mL
Estimate against measurement, compound 4: 1.5-fold (0.17 log units) below, within the range that was stated.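

In this assay, pentyl in place of hydrogen on the core of compound 3 gave a 1.5-fold higher number from compound 3 to compound 4 (0.18 log units; within the scatter), so this step, like the earlier one, stayed within the scatter. Set side by side, the two steps show that the change carried from one core to the other without a difference that can be told apart from the scatter: the same change on two cores in this assay, a 1.1-fold higher number (0.03 log units; within the scatter) from compound 1 to compound 2 and a 1.5-fold higher number (0.18 log units; within the scatter) from compound 3 to compound 4, 1.4-fold (0.15 log units) apart, within the scatter of two such steps. This holds only for these two pairs in this assay; it does not show that the change would behave alike on a further core, and it does not explain why both steps are small.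

The compounds shown leave open whether a longer chain such as decyl, or a pentyl chain ending in an amine or a carboxylic acid, would also pass between the two cores with so small a step. They also leave open what happens when an amine takes the place of the hydroxyl group on the side chain.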